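This account rests on a few compounds, and the source may have more. Where it says the series, first, only, none or still open, it means among the compounds named here.

Half-lives in an ADME assay on microsomes from liver (Homo sapiens) for metabolic stability, read by LC-MS, using NADPH, tested at 5 uM; a lower number here means that the compound disappears faster, a higher number that the compound lasts longer:
compound 1 `Cc1cccc(CSc2cc(Cl)c(C)cc2S(=O)(=O)/N=C(\N)n2nccc2-c2ccccc2)c1`, 0.232 h
compound 2 `Cc1cc(S(=O)(=O)/N=C(\N)n2nccc2-c2ccccc2)c(SCc2ccccc2)cc1Cl`, 0.0772 h
compound 3 `Cc1cc(-c2ccccc2)n(/C(N)=N/S(=O)(=O)c2cc(C)c(Cl)cc2SCc2ccc(C(F)(F)F)cc2)n1`, 0.241 h

Compound 3 gives the highest of the three numbers, though its gap to compound 1 lies within the scatter; only compound 2 stands clearly lower. Compound 4 `Cc1cc(S(=O)(=O)/N=C(\N)n2nccc2-c2ccccc2)c(SCc2ccc(C(F)(F)F)cc2)cc1Cl` differs from compound 3 by hydrogen in place of methyl on an aromatic carbon. For the measured compounds named here, one measured step bears on this change, and it is the same change made on the same core: a 3.0-fold lower number from compound 1 to compound 2 (0.48 log units; beyond the scatter). A step of about that size is therefore expected from compound 3 to compound 4, namely a 3.0-fold lower number from compound 3 to compound 4 (0.48 log units; beyond the scatter), towards a shorter half-life in this assay. For compound 4 the estimate is 0.08 h, with a range from 0.04 h to 0.16 h.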

Compound 4, half-life: 0.176 h
The estimate for compound 4 lay 2.2-fold (0.34 log units) below the measured number, and the stated range ends below it.
By their numbers in this assay, from the lowest: compound 2; then compounds 4, 1 and 3 (each within the scatter of the next).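

On the core bearing the 4-(trifluoromethyl)phenyl group, hydrogen in place of methyl on the five-membered aromatic ring gives a step within the scatter in this assay, a 1.4-fold lower number from compound 3 to compound 4 (0.14 log units; within the scatter), so a step beyond the scatter is not seen on every core. The two steps still cannot be told apart: the same change on two cores in this assay, a 3.0-fold lower number (0.48 log units; beyond the scatter) from compound 1 to compound 2 and a 1.4-fold lower number (0.14 log units; within the scatter) from compound 3 to compound 4, 2.2-fold (0.34 log units) apart, within the scatter of two such steps. Among the compounds without that methyl, trifluoromethyl in place of hydrogen gives a 2.3-fold higher number from compound 2 to compound 4 (0.36 log units; beyond the scatter), whereas 4-(trifluoromethyl)phenyl in place of 3-methylphenyl gives a 1.3-fold lower number from compound 1 to compound 4 (0.12 log units; within the scatter). The compounds shown leave open how an ethyl group or an amine on this ring carbon would read in this assay.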